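Oxime ether series: replacing pyridin-4-yl with cyano

The source may report more compounds than this note shows. Statements on the series, on what has been measured and on what is new or still open speak of the compounds shown alone.

Compounds with a measured inhibitory concentration:
Compound 1 `C/C(=N\OCc1ccncc1)c1ccc(Sc2cc(F)cc(C3CCOCC3)c2)cc1`, 300 nM
Compound 2 `COC1(c2csc(Sc3ccc4c(c3)CC/C4=N\OCC#N)c2)CCOCC1`, 40 nM
Compound 3 `COC1(c2csc(Sc3ccc4c(c3)CC/C4=N\O)c2)CCOCC1`, 130 nM

In a functional assay (blood) for inhibition, with Homo sapiens as the target (on this read-out higher numbers stand for weaker inhibition and lower numbers for stronger inhibition), compound 1 gives 300 nM, the highest number of the three; compound 3 sits closest to it, compound 2 furthest, both with lower numbers, and both gaps are beyond the scatter. Compound 4 `C/C(=N\OCC#N)c1ccc(Sc2cc(F)cc(C3CCOCC3)c2)cc1` has not yet been measured in this assay. It differs from compound 1 by cyano in place of pyridin-4-yl on a saturated chain carbon bound to an oxygen. The measured step closest to this change is the one within the other series, a 3.3-fold higher number from compound 2 to compound 3 (0.51 log units; beyond the scatter), where cyanomethyl on the oxygen gave the lower number and hydrogen the higher one. Within the data shown here, no measured pair compares a (pyridin-4-yl)methoxy group with a cyanomethoxy group directly, so the bearing of that step is only indirect. Since compound 2, the compound carrying cyanomethyl, gives 40 nM, the lowest number seen, a modest fall in this assay is expected for compound 4, a 2.0-fold lower number from compound 1 to compound 4 (0.30 log units; within the scatter). Compound 4 is therefore estimated at 150 nM, with a range from 50 nM to 450 nM.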

Compound 4, half-maximal inhibitory concentration: 20 nM
The estimate for compound 4 lay 7.5-fold (0.88 log units) above the measured number; measured number outside the range, below it.
By their numbers in this assay, from the lowest: compounds 4 and 2 (each within the scatter of the next); then compound 3; then compound 1.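

In this assay, the change on the saturated chain carbon bound to an oxygen proves to be a large one, a 15-fold lower number from compound 1 to compound 4 (1.18 log units; beyond the scatter), so this oxime ether position responds strongly to the group it carries in this core. The six-membered aromatic ring of pyridin-4-yl, with its 6 heavy atoms, is not needed for a low number here, since cyano, with 2 heavy atoms and no ring, gives the far lower reading. Nothing available here accounts for the size of this step.

The compounds shown leave open whether the nitrile itself matters or whether any small group would serve, which a plain methyl on the same oxygen would test. They also leave open how a longer chain, such as cyanoethyl, or a phenyl ring in place of pyridin-4-yl would read.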